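Alkyl variation on the oxygen next to the carbonyl group

The source may report more compounds than this note shows. Statements on the series, on what has been measured and on what is new or still open speak of the compounds shown alone.

Measured compounds in an assay on membranes from HeLa cells for displacement of a labelled ligand from adenosine receptor A3 (Homo sapiens), read by scintillation counting, with a stated time of 180 min, tested at 1 uM; a lower number here means less inhibition, a higher number more inhibition at the concentration tested (going by the name of the read-out):
compound 1 `CCCOC(=O)C1=C(C)NC(=O)NC1c1ccco1`: 3%
compound 2 `CCC(C)OC(=O)C1=C(C)NC(=O)NC1c1ccco1`: 3%
compound 3 `CC1=C(C(=O)OC2CCCCC2)C(c2ccco2)NC(=O)N1`: 4%

Compound 3 sits together with compound 1 and compound 2 within the scatter: a number 1 percentage points higher from compound 1 to compound 3 (within the scatter) and a number 1 percentage points higher from compound 2 to compound 3 (within the scatter). The third measured step, no change at the digits printed from compound 1 to compound 2 (within the scatter), also stays flat. Compound 4 `CC1=C(C(=O)OCC2CC2)C(c2ccco2)NC(=O)N1` differs from compound 3 in one place: cyclopropylmethyl in place of cyclohexyl on an oxygen next to a carbonyl group. Both steps that bear on it, from compound 1 and from compound 2 to compound 3, exchanged the group on that same oxygen and moved the number only within the scatter, so no step beyond the scatter is expected in this assay in either direction. Compound 4 is therefore expected to give about 4%, with a range from 0% to 12%. The estimated step is no change at the digits printed from compound 3 to compound 4 (within the scatter).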

Compound 4, a percentage reported as inhibition, at one concentration (the size of the read-out at that concentration, not a potency): 1%
Compound 4: middle estimate off by 3 percentage points, on the high side; the range from low to high includes it.
By their numbers in this assay, from the lowest: compounds 4, 1, 2 and 3 (each within the scatter of the next).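

In this assay, the cyclopropylmethyl group on the oxygen next to a carbonyl group gives no separation from the other groups: the number is unchanged within the scatter (a number 3 percentage points lower from compound 3 to compound 4 (within the scatter)), (a number 2 percentage points lower from compound 2 to compound 4 (within the scatter)) and (a number 2 percentage points lower from compound 1 to compound 4 (within the scatter)). The flat picture at this position now covers a three-membered ring as well as a six-membered ring and the open chains. Nothing at hand explains this flatness.

As far as these compounds go, whether an amine, a carboxylic acid or a longer chain on this oxygen would move the number beyond the scatter stays open. Changes elsewhere on the shared core also stay open.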